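This account rests on a few compounds, and the source may have more. Where it says the series, first, only, none or still open, it means among the compounds named here.

In a functional assay on T47D cells (Breast, Homo sapiens) for inhibition (on this read-out lower numbers stand for stronger inhibition of growth and higher numbers for weaker inhibition of growth), compound 2 `Cc1cc(-c2nc3cccc(F)c3s2)ccc1N` gives 20 nM, the lower of the two true numbers in this small set. The other number comes from compound 3 `Nc1ccc(-c2nc3cc(F)ccc3s2)cc1I`, which gives 130 nM, higher than compound 2 by more than the usual scatter. Compound 1 `Nc1ccc(-c2nc3ccc(F)cc3s2)cc1I` gives < 10 nM, which is a limit of the assay and not a number, so it cannot be ranked exactly against the others.

The next compound, compound 4 `Cc1cc(-c2nc3ccccc3s2)ccc1N`, is made from compound 2 by one small edit: hydrogen in place of fluoro on an aromatic carbon. Hydrogen takes the place of fluoro on an aromatic carbon, and the rest of the structure stays the same. For the measured compounds named here, no measured pair here shows this change alone, so the expectation is loose and starts from compound 2 at 20 nM.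

The expected change is small and within the scatter, leaning slightly towards stronger inhibition of growth: a 1.3-fold lower number from compound 2 to compound 4 (0.12 log units; within the scatter). For compound 4 the estimated value is 15 nM, with an expected range from 4 nM to 60 nM.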

Compound 4, concentration for 50% growth inhibition: 20 nM
Compound 4: the middle estimate sits 1.3-fold (0.12 log units) below what was measured, within the range that was stated.
By their numbers in this assay, from the lowest: compounds 2 and 4 (each within the scatter of the next); then compound 3. At a limit, below all of these: compound 1.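

Hydrogen in place of fluoro on this aromatic carbon gives no change at the digits printed from compound 2 to compound 4 (within the scatter) in this assay. For the compounds shown here, no earlier pair showed this change alone, and this pair shows that compound 2 does not need its fluoro group to keep this level of growth inhibition. Neither compound 2 nor compound 4 gives a limit of the assay, so this is a comparison of two true numbers, and the only limit in the set belongs to another compound: the limit of < 10 nM in this assay, at which 1 of the 4 values shown sits.

Going by these compounds, it remains open whether a different group on this carbon, such as chloro, methoxy, trifluoromethyl or an amine, would shift the number beyond the scatter. On these data alone, it is also open whether swapping fluoro for hydrogen would read the same way in a compound carrying iodo in place of the methyl group.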